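A few compounds are considered here, and "the series" means these few. Any claim that something is new, unique, unknown or untested is made for them only; others in the source may bear on it.

Measured so far in a functional assay on MGC-803 cells (Homo sapiens) for inhibition, read by MTT assay, with a stated time of 72 h; on this read-out higher numbers stand for weaker inhibition and lower numbers for stronger inhibition:
- compound 1, `Cc1cc(Nc2cc(-c3ccccc3)[nH]n2)n2nc(SCCc3ccccc3)nc2n1`: 5620 nM
- compound 2, `Cc1cc(Nc2cc(-c3ccccc3)[nH]n2)n2nc(SCc3ccc([N+](=O)[O-])cc3)nc2n1`: 4250 nM
- compound 3, `Cc1cc(Nc2cc(-c3ccccc3)[nH]n2)n2nc(SCC3CCCCC3)nc2n1`: 12600 nM

Compound 3 stands at the highest of these three numbers, so it is the weakest inhibitor of the three, with compound 1 nearest and compound 2 furthest. Compound 4 is `Cc1cc(Nc2cc(-c3ccccc3)[nH]n2)n2nc(SCc3ccccc3Br)nc2n1`, and the change from compound 3 is 2-bromophenyl in place of cyclohexyl on a saturated chain carbon bound to a sulfur. Among the compounds with values here, two measured steps bear on it, both ending at compound 3: a 2.2-fold higher number from compound 1 to compound 3 (0.35 log units; beyond the scatter) and a 3.0-fold higher number from compound 2 to compound 3 (0.47 log units; beyond the scatter). In both, replacing a six-membered aromatic ring by cyclohexyl gave a modestly higher number; the step to compound 4 runs the other way. A modest drop is therefore expected, a 2.5-fold lower number from compound 3 to compound 4 (0.40 log units; beyond the scatter). Compound 4 is estimated at 5000 nM, within 2500 nM to 10000 nM.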

Compound 4, half-maximal inhibitory concentration: 3650 nM
For compound 4 the middle estimate is 1.4-fold (0.14 log units) above the measured one; the measured number falls inside the stated range.
By their numbers in this assay, from the lowest: compounds 4, 2 and 1 (each within the scatter of the next); then compound 3.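

Across this position in this assay, 2-bromophenyl in place of cyclohexyl gives a clear but modest gain in inhibition (a 3.5-fold lower number from compound 3 to compound 4 (0.54 log units; beyond the scatter)), which leaves compound 3 beyond the scatter of all three compounds with an aromatic ring. Among those three, the new group cannot be told apart from 4-nitrophenyl (a 1.2-fold lower number from compound 2 to compound 4 (0.07 log units; within the scatter)) or benzyl (a 1.5-fold lower number from compound 1 to compound 4 (0.19 log units; within the scatter)), so the kind of ring substituent shows no effect here. No measurement at hand explains the gap to cyclohexyl. Still open, on these data alone, is how an amine or a carboxylic acid on the ring would behave, and whether 4-bromophenyl would match 2-bromophenyl.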